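The compounds below may be only part of what the source reports. "The series", "measured", "known", "first", "only" and "open" are said of these compounds alone.

Three compounds have so far been measured in a functional assay on PC-3 cells (Homo sapiens) for antiproliferative activity, read by MTT assay, with a stated time of 48 h; on this read-out lower numbers stand for stronger inhibition and higher numbers for weaker inhibition:

compound 1 `O=C(/C=C\Nc1ccc(F)cc1)c1cn(-c2ccccc2)nc1-c1ccccc1`: 7980 nM
compound 2 `O=C(/C=C\Nc1ccc(Cl)cc1)c1cn(-c2ccccc2)nc1-c1ccccc1`: 5200 nM
compound 3 `O=C(/C=C\Nc1ccc(O)cc1)c1cn(-c2ccccc2)nc1-c1ccccc1`: 3600 nM

Compound 3 gives the lowest of the three numbers in this assay, though a 1.4-fold lower number from compound 2 to compound 3 (0.16 log units; within the scatter) is within the scatter, while a 2.2-fold lower number from compound 1 to compound 3 (0.35 log units; beyond the scatter) is beyond it. Compound 4 `COc1ccc(N/C=C\C(=O)c2cn(-c3ccccc3)nc2-c2ccccc2)cc1` differs from compound 3 in one place: methyl in place of hydrogen on an oxygen on an aromatic ring. Among the compounds with values here, none of the measured steps makes this change. The two steps that end at compound 3 put hydroxy in place of fluoro or chloro on an aromatic carbon, and a 1.5-fold lower number from compound 1 to compound 2 (0.19 log units; within the scatter) exchanges fluoro for chloro; all three are small, and none touches the hydrogen on the oxygen. There is thus no direct basis for a step beyond the scatter, only a loose hint that this part of the structure moves the number little. For compound 4 the expected step is a 1.2-fold higher number from compound 3 to compound 4 (0.07 log units; within the scatter). Compound 4 is therefore estimated at 4200 nM, with a range from 1800 nM to 9500 nM.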

Compound 4, half-maximal inhibitory concentration: 6400 nM
The estimate for compound 4 lay 1.5-fold (0.18 log units) below the measured number, and the stated range covers the measured number.
By their numbers in this assay, from the lowest: compounds 3, 2, 4 and 1 (each within the scatter of the next, the first and the last beyond it).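

Within the data shown here, with this change the hydrogen on the oxygen is exchanged directly for the first time: in this assay the step is a 1.8-fold higher number from compound 3 to compound 4 (0.25 log units; within the scatter), so capping the hydroxy as methoxy does not take the number beyond the scatter. Methoxy also stays within the scatter of both halogens, with a 1.2-fold higher number from compound 2 to compound 4 (0.09 log units; within the scatter) and a 1.2-fold lower number from compound 1 to compound 4 (0.10 log units; within the scatter), so among the four groups on this aromatic carbon only the pair of compound 1 and compound 3 lies beyond it. Nothing shown here gives a reason for these numbers.

On these data alone, whether a longer chain on the oxygen, such as ethoxy, would stay in the same range remains open. So does the outcome with an amine or a carboxylic acid in place of the hydroxy.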